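Replacing the methoxy of compound 1 with hydrogen

The compounds below may be only part of what the source reports. "The series", "measured", "known", "first", "only" and "open" are said of these compounds alone.

In a functional assay on a cell-free system (Platelet, plasma, Oryctolagus cuniculus) for inhibition, with a stated time of 5 min, at 37 degrees C (on this read-out lower numbers stand for stronger inhibition and higher numbers for weaker inhibition), compound 1 (`COc1ccc(/C=C/C(=O)O)cc1OC(=O)c1nc(C)c(C)nc1C`) gives 41800 nM and compound 2 (`COc1cc(/C=C/C(=O)O)cc(OC)c1OC(=O)c1nc(C)c(C)nc1C`) gives 82300 nM, two values within the scatter of each other. Compound 3 (`CCOC(=O)/C=C/c1ccc(OC)c(OC(=O)c2nc(C)c(C)nc2C)c1`) gives 143000 nM, which sets it apart from compound 1: a 3.4-fold higher number from compound 1 to compound 3 (0.53 log units; beyond the scatter) is a modest step beyond the scatter, with ethyl in place of hydrogen on an oxygen next to a carbonyl group.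

Compound 4 (`Cc1nc(C)c(C(=O)Oc2cccc(/C=C/C(=O)O)c2)nc1C`) differs from compound 1 by hydrogen in place of methoxy on an aromatic carbon. Among the compounds with values here, the one measured step lies elsewhere in the molecule, so it gives only a rough scale for a single change. Within the data shown here, no measured step covers this replacement, so neither direction is well supported. In this assay the expected step is a 1.3-fold higher number from compound 1 to compound 4 (0.12 log units; within the scatter), with no change beyond the scatter anticipated. For compound 4 the estimated value is 55000 nM, with an expected range of 22000 nM to 140000 nM.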

Compound 4, half-maximal inhibitory concentration: 26400 nM
Compound 4: middle estimate off by 2.1-fold (0.32 log units), on the high side; low and high end bracket the measured number.
By their numbers in this assay, from the lowest: compounds 4, 1, 2 and 3 (each within the scatter of the next, the first and the last beyond it).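

In this assay, a 1.6-fold lower number from compound 1 to compound 4 (0.20 log units; within the scatter), so hydrogen in place of methoxy on this aromatic carbon, ortho to a large group and para to a 2-carboxyethenyl group, gives no change beyond the scatter. Compounds 1, 2 and 3 all carry a methoxy here, so they could not show how the series reads without it; compound 4 shows that this methoxy is not needed to keep the number within the scatter of compound 1. No available evidence bears on this result.

Open, as far as these compounds go, is whether a different group on this carbon, such as a hydroxyl, a fluorine or a longer ethoxy chain, would move the number beyond the scatter. Also open, from the compounds shown here alone, is whether the same replacement reads alike with the ethyl ester of compound 3.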